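From methyl to chloro: a question of cell toxicity

A few compounds are considered here, and "the series" means these few. Any claim that something is new, unique, unknown or untested is made for them only; others in the source may bear on it.

Within the data shown here, in an ADME assay on BJ cells (Homo sapiens) for cytotoxicity, with a stated time of 72 h (on this read-out lower numbers stand for an effect already at smaller amounts and higher numbers for an effect only at larger amounts of compound), compound 2 `Cc1ccc(-c2nc3c(c(C)nn3-c3ccccc3)c(-c3ccccc3O)c2C#N)cc1` gives 22200 nM, the only actual number available so far. Compound 1 `CCc1ccc(-c2nc3c(c(C)nn3-c3ccccc3)c(-c3ccccc3C(=O)O)c2C#N)cc1` is recorded only as a limit of the assay, > 20000 nM.

Compound 3 `Cc1nn(-c2ccccc2)c2nc(-c3ccc(Cl)cc3)c(C#N)c(-c3ccccc3O)c12` has not yet been measured. It differs from compound 2 in one place: chloro in place of methyl on an aromatic carbon. Put another way, 4-methylphenyl becomes 4-chlorophenyl. Among the measured compounds shown here, no two measured compounds differ in just one place, so the data offer no direct guide to this swap. The starting point is therefore compound 2 at 22200 nM. The expected change is small, with no clear direction and nothing beyond the usual scatter: a 1.1-fold lower number from compound 2 to compound 3 (0.05 log units; within the scatter). For compound 3, the estimated value is 20000 nM, with an expected range from 9000 nM to 42000 nM.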

Compound 3, half-maximal effective concentration: > 20000 nM
Compound 3 gave a limit, no number (the forecaster's own chance of this, stated with the estimate: 40%); the middle value lies on the limit itself.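

No step can be read from compound 2 to compound 3, because compound 3 is recorded only as a limit and not as a number: the limit of > 20000 nM in this assay, at which 2 of the 3 values shown sit. The compounds shown leave open whether chloro in place of methyl shifts the value at all, and in which direction.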